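This account rests on a few compounds, and the source may have more. Where it says the series, first, only, none or still open, it means among the compounds named here.

Measured in an ADME assay on cells (Homo sapiens) for cytotoxicity, read by polymerase chain reaction, with a stated time of 3 days; a higher number here means that more compound is tolerated, a lower number that less compound is tolerated:
- compound 1 `Cc1nc(N(C)C)nc(N[C@@H]2C[C@H](CO)[C@@H](O)[C@H]2O)c1-c1nc2cnccc2s1`: 25000 nM
- compound 2 `Cc1nc(NCC2CCN(C)CC2)nc(N[C@@H]2C[C@H](CO)[C@@H](O)[C@H]2O)c1-c1nc2cnccc2s1`: 25000 nM
- compound 3 `Cc1nc(Nc2ccccc2)nc(N[C@@H]2C[C@H](CO)[C@@H](O)[C@H]2O)c1-c1nc2cnccc2s1`: 25000 nM

Compound 1 stands level with compound 2 and compound 3 at the digits shown. Compound 4 `Cc1nc(N(C)Cc2ccccc2)nc(N[C@@H]2C[C@H](CO)[C@@H](O)[C@H]2O)c1-c1nc2cnccc2s1` is not yet measured in this assay. It follows from compound 1 by phenyl in place of hydrogen on a saturated chain carbon bound to a nitrogen on an aromatic ring, which turns dimethylamino into benzyl(methyl)amino.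

Among the measured compounds shown here, three measured steps bear on this change, all at the same place on the shared core: no change at the digits printed from compound 1 to compound 2 (within the scatter), no change at the digits printed from compound 1 to compound 3 (within the scatter) and no change at the digits printed from compound 2 to compound 3 (within the scatter). For the measured compounds named here, none goes beyond the scatter, and the closest precedent is the anilino group of compound 3, at 25000 nM. Going by the values given here, no measured compound carries benzyl(methyl)amino, so the range is left wider on the lower side. The expected step is no change at the digits printed from compound 1 to compound 4 (within the scatter), with no direction and nothing beyond the scatter anticipated. For compound 4 the estimated value is 25000 nM, with an expected range of 10000 nM to 30000 nM.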

Compound 4, half-maximal cytotoxic concentration: 25000 nM
Beside the measured number, compound 4's estimate shows no gap at the digits printed; measured number inside the range.
By their numbers in this assay, from the lowest: compounds 1, 2, 3 and 4 (each within the scatter of the next).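

In this assay, among the compounds shown here, phenyl in place of hydrogen on a saturated chain carbon bound to a nitrogen on an aromatic ring gives no change at the digits printed from compound 1 to compound 4 (within the scatter), which extends the flat picture at this position to benzyl(methyl)amino, the first group here that carries a phenyl ring on a saturated chain carbon. The comparisons with the other two amino groups read no change at the digits printed from compound 3 to compound 4 (within the scatter) and no change at the digits printed from compound 2 to compound 4 (within the scatter), so anilino, ((1-methylpiperidin-4-yl)methyl)amino and benzyl(methyl)amino cannot be told apart in this read-out. No supporting data accompany these values to explain the flat result.

The compounds shown leave open whether a carboxylic acid, a longer chain such as phenethyl, or a chlorine on the phenyl ring would shift the number at this position. Changes elsewhere on the shared core also remain open.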